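The compounds below may be only part of what the source reports. "The series", "measured", "known", "first", "only" and "open" are said of these compounds alone.

Measured in a functional assay on PC-3 cells (Homo sapiens) for antiproliferative activity, read by MTT assay, with a stated time of 48 h; on this read-out higher numbers stand for weaker inhibition and lower numbers for stronger inhibition:
Compound 1 `C#CC(C)OC(=O)c1ccc(C(CC)(CC)c2ccc(OCCC(O)(CC)CC)c(C)c2)n1CC`: 14800 nM
Compound 2 `CCC(C)C(NC(=O)c1ccc(C(CC)(CC)c2ccc(OCCC(O)(CC)CC)c(C)c2)n1CC)C(=O)OC`: > 50000 nM (a limit of the assay)
Compound 3 `CCn1c(C(=O)NC(C)C(=O)O)ccc1C(CC)(CC)c1ccc(OCCC(O)(CC)CC)c(C)c1`: 11700 nM

Compound 3 sits level with compound 1, a 1.3-fold lower number from compound 1 to compound 3 (0.10 log units; within the scatter), and well apart from compound 2, an at least 4.2-fold lower number from compound 2 to compound 3 (0.63 log units; beyond the scatter). Compound 4 `CCn1c(C(=O)NC(C)CO)ccc1C(CC)(CC)c1ccc(OCCC(O)(CC)CC)c(C)c1` carries hydroxymethyl in place of carboxy on a saturated chain carbon bound to an amide-type nitrogen and a saturated chain carbon. Going by the values given here, no measured step makes this exact change. The nearest guide is the change on the amide-type nitrogen, an at least 4.2-fold lower number from compound 2 to compound 3 (0.63 log units; beyond the scatter), which leaves room for a move to higher numbers. In this assay no step beyond the scatter is nevertheless the expectation, given a 1.3-fold lower number from compound 1 to compound 3 (0.10 log units; within the scatter). The expected step is a 1.4-fold higher number from compound 3 to compound 4 (0.14 log units; within the scatter). The estimate for compound 4 is 16000 nM, with an expected range of 6000 nM to 45000 nM.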

Compound 4, half-maximal inhibitory concentration: 7870 nM
For compound 4 the middle estimate is 2.0-fold (0.31 log units) above the measured one; the range from low to high includes it.
By their numbers in this assay, from the lowest: compounds 4, 3 and 1 (each within the scatter of the next). At a limit, above all of these: compound 2.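

In this assay, carboxy on this saturated chain carbon gives way to hydroxymethyl without a move beyond the scatter (a 1.5-fold lower number from compound 3 to compound 4 (0.17 log units; within the scatter)), so the free carboxy group is not needed here to hold the number. The same holds for (1-(hydroxymethyl)ethyl)amino in place of (1-methylprop-2-yn-1-yl)oxy on the carbonyl carbon (a 1.9-fold lower number from compound 1 to compound 4 (0.27 log units; within the scatter)), while the gap to the larger group on the amide-type nitrogen widens (an at least 6.3-fold lower number from compound 2 to compound 4 (0.80 log units; beyond the scatter)). Compound 2 stands at a limit, not a number: the limit of > 50000 nM in this assay, at which 1 of the 4 values shown sits.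

Still open, as far as these compounds go, is whether aminomethyl or a methyl ester on this saturated chain carbon would leave the number equally unmoved. From the compounds shown here alone, a longer chain ending in hydroxyl at this place is equally open.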